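The source may hold more compounds than are shown below. What is called first, only, known or untested is meant among the compounds shown, and "the series" means these compounds.

Measured so far in an ADME assay on HEp-2 cells (Homo sapiens) for cytotoxicity, read by MTT assay, with a stated time of 72 h; on this read-out higher numbers stand for weaker inhibition and lower numbers for stronger inhibition:
- compound 1 `COc1ccc(C2=C(c3cc(OC)c(OC)c(OC)c3)C(=O)C(OC(C)=O)C2)cc1` gives 18 ug/mL
- compound 2 `COc1ccc(C2=C(c3cc(OC)c(OC)c(OC)c3)C(=O)C(O)C2)cc1` gives < 1 ug/mL
- compound 3 `CC(=O)OC1C/C(=N/O)C(c2ccccc2)=C1c1ccccc1` gives > 100 ug/mL

Compound 1 and compound 2 share a core and differ in one spot: hydrogen in place of acetyl on an oxygen on a saturated carbon. This change gives an at least 18-fold lower number from compound 1 to compound 2 (1.25 log units; beyond the scatter). The value of compound 2 is a limit of this assay, not a number, as recorded in the limit of < 1 ug/mL in this assay, at which 1 of the 3 values shown sits. The value of compound 3 is also a limit of this assay, not a number, as recorded in the limit of > 100 ug/mL in this assay, at which 1 of the 3 values shown sits.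

Compound 4 `O/N=C1/CC(O)C(c2ccccc2)=C1c1ccccc1` has not yet been measured. It differs from compound 3 in the same way that compound 2 differs from compound 1: hydrogen in place of acetyl on an oxygen on a saturated carbon. The surroundings of the change are the same in both pairs, so this is the same change made on a different core. How the core of compound 3 differs from the core of compound 1 is not broken down here.

For the measured compounds named here, with only one earlier example of this change, and with compound 3 sitting at a limit rather than at a number, the expected size of the step in this assay is uncertain; still, the expected direction follows the earlier one, so the step from compound 3 to compound 4 is estimated as an at least 2.5-fold lower number from compound 3 to compound 4 (0.39 log units; beyond the scatter), which rests on an at least 18-fold lower number from compound 1 to compound 2 (1.25 log units; beyond the scatter). Compound 4 is thus expected to give about 40 ug/mL, somewhere between 5 ug/mL and 150 ug/mL.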

Compound 4, half-maximal inhibitory concentration: > 100 ug/mL
Compound 4 gave a limit, no number; the forecaster's own chance of this, stated with the estimate: 40%; middle value at least 2.5-fold (0.39 log units) away from the limit.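

In this assay, compound 3 and compound 4 both sit at the same limit rather than at a number, so the step between them cannot be read: the limit of > 100 ug/mL in this assay, at which 2 of the 4 values shown sit.

The compounds shown leave open whether the change from acetoxy to hydroxy does anything on the core of compound 3 that compares with an at least 18-fold lower number from compound 1 to compound 2 (1.25 log units; beyond the scatter).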